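Fluoro on the phenyl of compound 1

The source may report more compounds than this note shows. Statements on the series, on what has been measured and on what is new or still open speak of the compounds shown alone.

The series shares one core; the compounds differ in the group carried on the saturated chain carbon bound to a nitrogen on an aromatic ring. In a functional assay on MCF-10A cells (Homo sapiens) for antiproliferative activity, with a stated time of 48 h (on this read-out lower numbers stand for an effect already at smaller amounts and higher numbers for an effect only at larger amounts of compound), compound 1 `COc1ccc2nc(C)cc(NCc3ccccc3)c2c1` gives 28600 nM, the second highest of the three numbers. Compound 2 `COc1ccc2nc(C)cc(NCc3ccncc3)c2c1` gives 41600 nM, and the step is a 1.5-fold higher number from compound 1 to compound 2 (0.16 log units; within the scatter). For the measured compounds named here, compound 3 `COc1ccc2nc(C)cc(NCC3CCCN(C)C3)c2c1` gives 5800 nM; the step of a 4.9-fold lower number from compound 1 to compound 3 (0.69 log units; beyond the scatter) is the only one from compound 1 that goes beyond the scatter, and a 7.2-fold lower number from compound 2 to compound 3 (0.86 log units; beyond the scatter) points the same way.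

Compound 4 `COc1ccc2nc(C)cc(NCc3ccccc3F)c2c1` differs from compound 1 by fluoro in place of hydrogen on an aromatic carbon. Going by the values given here, none of the measured steps bears directly on this change: each of them exchanges the whole ring, whereas here the phenyl is kept and one fluorine is added to it. The ring exchanges show that phenyl and pyridin-4-yl give numbers close to each other in this assay, and that only the 1-methylpiperidin-3-yl moves the read-out beyond the scatter. Among the compounds with values here, with no measured step of this kind, a step of the size a 1.1-fold lower number from compound 1 to compound 4 (0.04 log units; within the scatter) is expected, that is, none beyond the scatter. Compound 4 is estimated at 26000 nM, with a range of 12000 nM to 60000 nM.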

Compound 4, half-maximal effective concentration: 17000 nM
Estimate against measurement, compound 4: 1.5-fold (0.18 log units) above, and the stated range covers the measured number.
By their numbers in this assay, from the lowest: compound 3; then compounds 4, 1 and 2 (each within the scatter of the next, the first and the last beyond it).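

Fluoro in place of hydrogen on an aromatic carbon, ortho to a large group, is the first change in the series that keeps the phenyl, and in this assay it gives a 1.7-fold lower number from compound 1 to compound 4 (0.23 log units; within the scatter), so this addition shifts the read-out by no more than the scatter. Compound 4 nevertheless separates from the pyridin-4-yl compound with a 2.4-fold lower number from compound 2 to compound 4 (0.39 log units; beyond the scatter), a gap that compound 1 did not show, while a 2.9-fold higher number from compound 3 to compound 4 (0.47 log units; beyond the scatter) leaves the 1-methylpiperidin-3-yl of compound 3 with the lowest number of the four. No independent measurement bears on what lies behind these numbers.

As far as these compounds go, whether a chloro, a methoxy or an amine on the same aromatic carbon would stay within the scatter of compound 1 remains open, as does the outcome of fluoro on the other carbons of the phenyl. From the compounds shown here alone, it is also open whether a longer chain between the nitrogen and the 2-fluorophenyl would bring the number closer to that of compound 3.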